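Trifluoromethoxy removal in a chloro-dithiazole imine series

The compounds below may be only part of what the source reports. "The series", "measured", "known", "first", "only" and "open" are said of these compounds alone.

Measured compounds:
compound 1 `CCCCOc1ccc(/N=c2\ssnc2Cl)cc1` gives 42000 nM in a functional assay on MCF7 cells (Homo sapiens) for cytotoxicity, read by resazurin assay, with a stated time of 72 h; on this read-out higher numbers stand for weaker inhibition and lower numbers for stronger inhibition
compound 2 `FC(F)(F)Oc1ccc(/N=c2\ssnc2Cl)cc1Br` gives 73000 nM in this assay
compound 3 `CSc1ccc(/N=c2\ssnc2Cl)cc1` gives 36000 nM in this assay

Compound 2 holds the highest number of the three. Its gap to compound 1 lies within the scatter, so no order between these two is claimed; its gap to compound 3 lies beyond the scatter.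

Compound 4 `Clc1nss/c1=N\c1cccc(Br)c1` has not yet been measured. It differs from compound 2 by hydrogen in place of trifluoromethoxy on an aromatic carbon; the bromo group stays. For the measured compounds named here, only one measured step is on hand, a 1.2-fold lower number from compound 1 to compound 3 (0.07 log units; within the scatter), and it concerns an exchange of one group for another at a different position, not a removal of trifluoromethoxy; it therefore bears on the present change only loosely.

Going by the values given here, the one step stayed within the scatter, and no measured compound shows the effect of removing trifluoromethoxy, so the expected step is a 1.2-fold lower number from compound 2 to compound 4 (0.09 log units; within the scatter), not beyond the scatter in either direction. For compound 4 the estimated value in this assay is 60000 nM, expected to fall between 25000 nM and 150000 nM.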

Compound 4, half-maximal inhibitory concentration: 6700 nM
The estimate for compound 4 lay 9.0-fold (0.95 log units) above the measured number; the measured number lies below the stated range.
By their numbers in this assay, from the lowest: compound 4; then compounds 3, 1 and 2 (each within the scatter of the next, the first and the last beyond it).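

Hydrogen in place of trifluoromethoxy, at the carbon ortho to a bromo group and para to a group of 7 heavy atoms, gives an 11-fold lower number from compound 2 to compound 4 (1.04 log units; beyond the scatter) in this assay. For the compounds shown here, this position therefore responds strongly to this change, whereas the only earlier step, a 1.2-fold lower number from compound 1 to compound 3 (0.07 log units; within the scatter), gave no sign of a shift of this size. Trifluoromethoxy is also not needed at this carbon for the lower number, and no available measurement explains the step.

The compounds shown leave open whether the lower number belongs to hydrogen alone or would persist with a methoxy group, a fluorine atom or an amine at this carbon. They also leave open what the bromo group contributes, since every comparison at this carbon keeps it in place.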